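A few compounds are considered here, and "the series" means these few. Any claim that something is new, unique, unknown or untested is made for them only; others in the source may bear on it.

Measured so far in a functional assay on MCF7 cells (Homo sapiens) for antiproliferative activity, read by MTT assay, with a stated time of 48 h; a lower number here means a stronger inhibitor, a higher number a weaker inhibitor:
- compound 1 `O=C(/C=C/c1ccc(O)c(O)c1)N1CCN(c2ccccc2Cl)CC1`: 1.36 ug/mL
- compound 2 `COc1cccc(N2CCN(C(=O)/C=C/c3ccc(O)c(O)c3)CC2)c1`: 0.92 ug/mL

Compound 2, at 0.92 ug/mL, stands within the scatter of compound 1, so the two numbers set no order between them. Compound 3 `COc1ccc(N2CCN(C(=O)/C=C/c3ccc(O)c(O)c3)CC2)cc1` is not yet measured in this assay. It differs from compound 2 in one place, with 4-methoxyphenyl in place of 3-methoxyphenyl on an amine nitrogen in a ring. The two have the same atoms, joined differently.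

For the measured compounds named here, only one measured step bears on this change, and it also alters the group on that amine nitrogen: a 1.5-fold lower number from compound 1 to compound 2 (0.17 log units; within the scatter). That step stays within the scatter, but it is a single step and it exchanges a different pair of groups. Going by the values given here, no measured pair shows what moving the methoxy group does, so the evidence is thin. No step beyond the scatter is expected, in either direction. The expected step is a 1.1-fold higher number from compound 2 to compound 3 (0.04 log units; within the scatter). Compound 3 is estimated at 1 ug/mL, with an expected range of 0.45 ug/mL to 2.2 ug/mL.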

Compound 3, half-maximal inhibitory concentration: 0.52 ug/mL
Compound 3: middle estimate off by 1.9-fold (0.28 log units), on the high side; measured number inside the range.
By their numbers in this assay, from the lowest: compounds 3, 2 and 1 (each within the scatter of the next, the first and the last beyond it).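

Within this assay, the move of the methoxy group gives the first direct reading on this place, three ring bonds from the ring nitrogen: a 1.8-fold lower number from compound 2 to compound 3 (0.25 log units; within the scatter) leaves 4-methoxyphenyl and 3-methoxyphenyl on the amine nitrogen without an order between them. For the compounds shown here, the exchange of 2-chlorophenyl for 4-methoxyphenyl gives a 2.6-fold lower number from compound 1 to compound 3 (0.42 log units; beyond the scatter) and is the first step to pass beyond the scatter, so the group on this nitrogen can shift the number, though only modestly so far. No measurement available here accounts for either step.

The compounds shown do not separate the effect of the substituent from the effect of its place on the phenyl ring, since 2-chlorophenyl and 4-methoxyphenyl differ in both. Also open, going by these compounds, is how an unsubstituted phenyl, or a phenyl ring carrying an amine or a carboxylic acid, would read on the same nitrogen in this assay, and so whether methoxy itself contributes anything to these numbers.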